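Lengthening the Acyl Chain of Compound 1

The source may report more compounds than this note shows. Statements on the series, on what has been measured and on what is new or still open speak of the compounds shown alone.

Compound 1 `COc1ccc(CN(C(C)=O)c2cc(OC)c(OC)c(OC)c2)cc1O` gives 160 nM
Compound 2 `COc1cc(NCc2ccc(Cl)cc2)cc(OC)c1OC` gives > 80000 nM
Compound 3 `C/C=C/C(=O)N(Cc1ccc(OC)c(N)c1)c1cc(OC)c(OC)c(OC)c1` gives 310 nM

All three compounds were tested in a functional assay on KYSE-450 cells (Homo sapiens) for inhibition, read by MTT assay, with a stated time of 48 h; a lower number here means a stronger inhibitor, a higher number a weaker inhibitor. Compound 1 and compound 3 lie within the usual scatter of each other, so these two cannot be ranked. Compound 2 reads > 80000 nM, which is a limit and not a number.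

The next compound, compound 4 `C/C=C/C=C/C(=O)N(Cc1ccc(OC)c(O)c1)c1cc(OC)c(OC)c(OC)c1`, has not yet been measured. It differs from compound 1 by one change, (penta-1,3-dien-1-yl in place of methyl on a carbonyl carbon), with penta-1,3-dien-1-yl in place of methyl on a carbonyl carbon. Among the compounds with values here, no measured pair tests this change, so the guide is thin. The expectation rests only on the numbers for compound 1 at 160 nM and compound 3 at 310 nM. In this assay a modest move toward a higher number, meaning a somewhat weaker inhibitor, is expected: a 1.9-fold higher number from compound 1 to compound 4 (0.27 log units; within the scatter). For compound 4 the estimated value is 300 nM, with an expected range from 60 nM to 1500 nM.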

Compound 4, half-maximal inhibitory concentration: 180 nM
Beside the measured number, compound 4's estimate is 1.7-fold (0.22 log units) above it; low and high end bracket the measured number.
By their numbers in this assay, from the lowest: compounds 1, 4 and 3 (each within the scatter of the next). At a limit, above all of these: compound 2.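

Within the data shown here, until now, no measured pair tested this place, the carbonyl carbon whose other neighbour is the amide-type nitrogen. In this assay, the change from acetyl to (penta-1,3-dien-1-yl)carbonyl provides that test, and it puts a chain of 5 carbons with 2 double bonds in place of a single methyl without a shift that can be told from scatter (a 1.1-fold higher number from compound 1 to compound 4 (0.05 log units; within the scatter)). This one pair shows that the place can carry the larger chain with the reading held, but the compounds shown offer no explanation for that result.

Going by these compounds, whether the double bonds matter remains open, and a saturated pentyl chain would address that. A chain ending in an amine or a carboxylic acid would show whether this place accepts other kinds of group as well.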